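A halogen swap on the distal aryl ring

The source may hold more compounds than are shown below. What is called first, only, known or untested is meant among the compounds shown, and "the series" means these compounds.

Among the compounds with values here, compound 3 `O=C(O)c1ccc(CCCN2C(=O)CC[C@@H]2CC[C@@H](O)Cc2ccc(F)cc2)s1` is the one compound among the three that returns a number in an assay on HEK293 cells for binding affinity to prostaglandin E2 receptor EP2 subtype (Rattus norvegicus); a higher number here means a weaker inhibitor, a lower number a stronger inhibitor: compound 3 gives 1210 nM. Compound 1 `O=C(O)CCCCCCN1C(=O)CC[C@@H]1CC[C@@H](O)CCc1ccccc1` returns only a limit in this assay, > 3200 nM, which is a limit of the assay and not a number. Compound 2 `O=C(O)c1ccc(CCCN2C(=O)CCC2CCC(O)Cc2ccc(F)cc2)cc1` likewise returns only a limit, > 3200 nM. Within the data shown here, the shared picture is the limit of > 3200 nM in this assay, at which 2 of the 3 values shown sit, so compound 3 stands apart as the sole compound with a measured value, and it is the only anchor for what follows.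

Compound 4 `O=C(O)c1ccc(CCCN2C(=O)CC[C@@H]2CC[C@@H](O)Cc2cccc(Cl)c2)s1` differs from compound 3 in one place: 3-chlorophenyl in place of 4-fluorophenyl on a saturated chain carbon, two bonds along the chain from an oxygen on a saturated carbon. Among the measured compounds shown here, no pair of measured compounds differs by this change alone, so there is no measured step of this kind to lean on. With only compound 3 as a reference, the expected step is modest, with no clear direction beyond the usual scatter, and the reading of compound 4 is expected to remain in the same region rather than fall back to a limit.

On that basis compound 4 is estimated at 1000 nM, with a range from 400 nM to 3200 nM, which corresponds to an expected step of a 1.2-fold lower number from compound 3 to compound 4 (0.08 log units; within the scatter).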

Compound 4, half-maximal inhibitory concentration: 188 nM
Estimate against measurement, compound 4: 5.3-fold (0.73 log units) above, outside the stated range (below it).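

Swapping 4-fluorophenyl for 3-chlorophenyl on a saturated chain carbon, two bonds along the chain from an oxygen on a saturated carbon, gives a 6.4-fold lower number from compound 3 to compound 4 (0.81 log units; beyond the scatter) in this assay while the rest of the molecule stays the same. Within the data shown here, this is the first step that can be read as a number, and it shows that this position can move the reading beyond the scatter, even though both groups count the same heavy atoms, with no hydrogen-bond donors or acceptors and no net charge. The other compounds give no comparison with this change, and their readings remain limits of the assay, not numbers: the limit of > 3200 nM in this assay, at which 2 of the 4 values shown sit.

The swap changes both the halogen and its place on the ring at once, and the compounds shown cannot tell how much of the step belongs to the chlorine and how much to its place. They also leave open how a plain phenyl group or a bromine-bearing phenyl group at this carbon would read, and whether the same swap would give a similar step on the cores of the other compounds.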